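Pyrazoline sulfonamides: swapping the saturated-carbon aryl group

This account rests on a few compounds, and the source may have more. Where it says the series, first, only, none or still open, it means among the compounds named here.

Measured compounds in a functional assay on CCRF-CEM cells (Homo sapiens) for antiproliferative activity, with a stated time of 48 h; a lower number here means a stronger inhibitor of growth, a higher number a weaker inhibitor of growth:
compound 1 `Cc1cc(O)c(C2=NN(c3ccc(S(N)(=O)=O)cc3)C(c3ccccc3O)C2)cc1Cl` gives 4170 nM
compound 2 `Cc1cc(O)c(C2=NN(c3ccc(S(N)(=O)=O)cc3)C(c3ccccc3Cl)C2)cc1Cl` gives 4810 nM
compound 3 `Cc1cc(O)c(C2=NN(c3ccc(S(N)(=O)=O)cc3)C(/C=C/c3ccccc3)C2)cc1Cl` gives 17700 nM

Compound 3 stands at the top of the three numbers, that is the weakest growth inhibitor on this set. Its nearest neighbour is compound 2, with a 3.7-fold higher number from compound 2 to compound 3 (0.57 log units; beyond the scatter), and the furthest is compound 1, with a 4.2-fold higher number from compound 1 to compound 3 (0.63 log units; beyond the scatter). Between the two aryl-bearing compounds the difference is small: a 1.2-fold higher number from compound 1 to compound 2 (0.06 log units; within the scatter).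

Compound 4 `COc1ccc(C2CC(c3cc(Cl)c(C)cc3O)=NN2c2ccc(S(N)(=O)=O)cc2)cc1OC` is not yet measured. It differs from compound 3 by 3,4-dimethoxyphenyl in place of 2-phenylethenyl on a saturated ring carbon.

Going by the values given here, two measured steps bear on this change, since both replace an aryl group on that same saturated ring carbon by the 2-phenylethenyl group and both raise the number by a modest, beyond-scatter amount. Going the other way, from 2-phenylethenyl back to an aryl group, the expectation is therefore a modest fall in this assay, of about the size seen in those two steps. Among the compounds with values here, the 3,4-dimethoxyphenyl group itself has no measured counterpart here, so the ortho-substitution pattern of compounds 1 and 2 is not directly matched, and the range is kept wide.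

For compound 4 the estimate is 6000 nM, with a range from 2500 nM to 15000 nM. This means an expected step of a 3.0-fold lower number from compound 3 to compound 4 (0.47 log units; beyond the scatter).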

Compound 4, concentration for 50% growth inhibition: 5350 nM
Compound 4: the middle estimate sits 1.1-fold (0.05 log units) above what was measured, within the range that was stated.
By their numbers in this assay, from the lowest: compounds 1, 2 and 4 (each within the scatter of the next); then compound 3.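

In this assay the step of a 3.3-fold lower number from compound 3 to compound 4 (0.52 log units; beyond the scatter) shows that the fall on leaving 2-phenylethenyl does not depend on the 2-hydroxyphenyl or 2-chlorophenyl group, since a phenyl ring carrying two methoxy groups gives it as well. The 3,4-dimethoxyphenyl group, with its 2 hydrogen-bond acceptors, also stands level with both earlier aryl groups on this saturated ring carbon (a 1.1-fold higher number from compound 2 to compound 4 (0.05 log units; within the scatter) and a 1.3-fold higher number from compound 1 to compound 4 (0.11 log units; within the scatter)), so these three aryl groups cannot be told apart here and, among the four compounds, only compound 3 stands apart. No measured information accompanies these numbers that could explain the level shared by the aryl compounds or the separate position of compound 3.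

Open, going by these compounds, is whether the level shared by compounds 1, 2 and 4 is kept when this carbon carries something other than an aryl group, such as a simple butyl chain, an amine or a carboxylic acid. Also open, on these data alone, is whether 2-phenylethyl, which lacks the double bond of 2-phenylethenyl, stays with compound 3 or joins the aryl compounds.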